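Compound 1 to compound 3: hydroxy on the amide-type nitrogen

The compounds below may be only part of what the source reports. "The series", "measured", "known", "first", "only" and "open" are said of these compounds alone.

- Compound 1 `COc1cc(NC(C)CCCNC(=O)NCCO)c2ncccc2c1`: > 100000 nM
- Compound 2 `COc1cc(NC(C)CCCNC(=O)NC(CO)(CO)CO)c2ncccc2c1`: > 100000 nM

In a functional assay on MOLT-4 cells (Homo sapiens) (a lower number here means a stronger inhibitor, a higher number a weaker inhibitor), compound 1 gives > 100000 nM, which is a limit of the assay and not a number. Compound 2 gives > 100000 nM, which is likewise a limit. The two compounds together stand at the limit of > 100000 nM in this assay, at which 2 of the 2 values shown sit, so the series has no numerical starting point yet.

Compound 3 `COc1cc(NC(C)CCCNC(=O)NO)c2ncccc2c1` keeps the shared core and differs from compound 1 by hydroxy in place of 2-hydroxyethyl on an amide-type nitrogen. For the measured compounds named here, the only measured step at this nitrogen is a step that the two limits leave unreadable from compound 1 to compound 2. It has no size to carry over, so it offers no guide to the size of the new step.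

Since compound 1 sits at a limit, any readable value for compound 3 would mean a stronger inhibitor in this assay, although a result at the same limit remains quite possible. The expected change, held with little confidence, is an at least 2.5-fold lower number from compound 1 to compound 3 (0.39 log units; beyond the scatter). The estimated value for compound 3 is 40000 nM, with an expected range from 8000 nM to 100000 nM.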

Compound 3, half-maximal inhibitory concentration: > 100000 nM
Compound 3: a limit, no number; the forecaster's own chance of this, stated with the estimate: 40%; at least 2.5-fold (0.39 log units) between middle value and limit.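

In this assay compound 3 gives > 100000 nM, a limit and not a number. No step among compound 1, compound 2 and compound 3 can be read, and the series still has no numerical value: the limit of > 100000 nM in this assay, at which 3 of the 3 values shown sit.

The compounds shown leave open which group on the amide-type nitrogen, if any, would give a readable value in this assay.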